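Two Inactive Compounds and a Phenyl-for-Methyl Exchange

The compounds below may be only part of what the source reports. "The series", "measured", "known", "first", "only" and "open" are said of these compounds alone.

Measured so far:
- compound 1, `O=C(NNc1nc(-c2ccccc2)c[se]1)c1ccccc1`: > 73000 nM
- compound 2, `Cc1c[se]c(NNC(=O)c2ccc(Cl)cc2)n1`: > 79400 nM

Both values come from a functional assay on DU-145 cells (Homo sapiens) for cytotoxicity, read by XTT assay, with a stated time of 72 h; a higher number here means a weaker inhibitor, a lower number a stronger inhibitor. For compound 1 the value > 73000 nM is a limit of the assay, not a number. For compound 2 the value > 79400 nM is likewise a limit, not a number. Compound 2 therefore stands at the edge of what this assay can report, (the limit of > 79400 nM in this assay, at which 1 of the 2 values shown sits), and compound 1 sits at the corresponding edge for its own measurement, (the limit of > 73000 nM in this assay, at which 1 of the 2 values shown sits). Neither compound shows measurable cytotoxicity within the tested range.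

The next compound, compound 3, `O=C(NNc1nc(-c2ccccc2)c[se]1)c1ccc(Cl)cc1`, differs from compound 2 in one place: phenyl in place of methyl on an aromatic carbon. Compound 1 already carries this phenyl group on its shared core and still gives only a limit, so the exchange on its own has not produced a measurable value anywhere among these compounds.

Compound 3 is therefore expected to remain at or beyond the limit, with a step that the limit leaves unreadable from compound 2 to compound 3 that is expected to be none beyond the scatter. The estimate for compound 3 in this assay is 80000 nM, within a range from 30000 nM to 200000 nM.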

Compound 3, half-maximal inhibitory concentration: 65100 nM
Compound 3: the middle estimate sits 1.2-fold (0.09 log units) above what was measured; the measured number falls inside the stated range.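

In this assay, for the compounds shown here, compound 3 is the first compound here to give a number rather than a limit, and it is also the one that carries both the phenyl of compound 1 and the chloro of compound 2; phenyl in place of methyl on the aromatic carbon gives an at least 1.2-fold lower number from compound 2 to compound 3 (0.08 log units; that floor lies within the scatter), while chloro in place of hydrogen gives an at least 1.1-fold lower number from compound 1 to compound 3 (0.04 log units; that floor lies within the scatter). The true size of the first step cannot be read because compound 2 gives only a limit: the limit of > 79400 nM in this assay, at which 1 of the 3 values shown sits. The true size of the second step cannot be read either, because compound 1 also gives only a limit: the limit of > 73000 nM in this assay, at which 1 of the 3 values shown sits.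

So neither change can yet be said to lower the number by more than the usual scatter, and the data cannot separate what the phenyl and the chloro each contribute. The compounds shown leave open whether a longer chain such as propyl at the place of the methyl, or an amine or a carboxylic acid at the place of the chloro, would move the number clearly beyond that scatter.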